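Replacing the Chain End of a Crotonamide with a Ring Amine

The source may report more compounds than this note shows. Statements on the series, on what has been measured and on what is new or still open speak of the compounds shown alone.

Compound 3 `CCC/C=C/C(=O)Nc1cc2c(N3CCCc4ccccc43)ncnc2cc1OC` gives 1210 nM in a functional assay on MCF7 cells (Homo sapiens) for antiproliferative activity, read by MTT assay, with a stated time of 72 h; a higher number here means a weaker inhibitor, a lower number a stronger inhibitor.
Compound 1 `COc1cc2ncnc(N3CCCc4ccccc43)c2cc1NC(=O)C=C(C)C` gives 6870 nM.
Compound 2 `C/C=C/C(=O)Nc1cc2c(N3CCCc4ccccc43)ncnc2cc1OC` gives 12700 nM.

Among the three measured compounds, compound 3 carries the lowest number in this assay, and both gaps to it are beyond the scatter: compound 1 sits above it by a 5.7-fold lower number from compound 1 to compound 3 (0.75 log units; beyond the scatter) read in reverse, and compound 2 further still, by a 10-fold lower number from compound 2 to compound 3 (1.02 log units; beyond the scatter) read in reverse. Compound 4 `COc1cc2ncnc(N3CCCc4ccccc43)c2cc1NC(=O)/C=C/CN1CCCC1` has not yet been measured. It differs from compound 3 in one place: pyrrolidin-1-yl in place of ethyl on a saturated chain carbon bound to a double-bonded chain carbon. Going by the values given here, the steps that bear on this position are the two that reach compound 3. Lengthening the chain end from hydrogen to ethyl gave a 10-fold lower number from compound 2 to compound 3 (1.02 log units; beyond the scatter), a large step, and exchanging a branched chain end for the longer one gave a 5.7-fold lower number from compound 1 to compound 3 (0.75 log units; beyond the scatter), a modest step. Neither step, however, tests a ring or a nitrogen at this place, so the direction of the change in compound 4 cannot be read from them. The expectation is therefore a step of a 1.2-fold higher number from compound 3 to compound 4 (0.09 log units; within the scatter), with a wide spread. Compound 4 is estimated at 1500 nM, with a range from 400 nM to 6000 nM.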

Compound 4, half-maximal inhibitory concentration: 3190 nM
For compound 4 the middle estimate is 2.1-fold (0.33 log units) below the measured one; the range from low to high includes it.
By their numbers in this assay, from the lowest: compound 3; then compound 4; then compounds 1 and 2 (each within the scatter of the next).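

In this assay, this first ring amine at the saturated chain carbon bound to a double-bonded chain carbon shows that the place accepts more than a short carbon chain: pyrrolidin-1-yl still gives a 4.0-fold lower number from compound 2 to compound 4 (0.60 log units; beyond the scatter), so the gain over hydrogen is not limited to ethyl, although it is smaller than the gain with ethyl. The ring also keeps the compound ahead of the branched chain end, with a 2.2-fold lower number from compound 1 to compound 4 (0.33 log units; beyond the scatter), yet it does not match the ethyl end, as a 2.6-fold higher number from compound 3 to compound 4 (0.42 log units; beyond the scatter) shows, so a larger group with a ring and a nitrogen brings no advance over ethyl here. No measurement available for these compounds offers an explanation for these differences.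

The compounds shown cannot separate the effect of the ring from that of its nitrogen: cyclopentyl would keep the ring without the nitrogen, and an open-chain diethylamino group would keep the nitrogen without the ring. From the compounds shown here alone, how a six-membered ring amine such as piperidin-1-yl or morpholin-4-yl, or a chain longer than ethyl, would fare at this place also remains open.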